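The source may hold more compounds than are shown below. What is called first, only, known or untested is meant among the compounds shown, and "the series" means these compounds.

In a functional assay for inhibition, with Cavia porcellus as the target (a lower number here means a stronger inhibitor, a higher number a weaker inhibitor), compound 3 (`CCCCOc1cc(C(=O)Nc2c(Cl)cncc2Cl)ccc1OC`) gives 480 nM, within the scatter of compound 1 (`COc1ccc(C(=O)Nc2ccccc2Cl)cc1OC1CCCC1`) at 450 nM. Compound 2 (`COc1ccc(C(=O)Nc2ccncc2Cl)cc1OC1CCCC1`) at 30 nM lies well beyond the scatter from both. Compound 4 (`COc1ccc(C(=O)Nc2c(Cl)cncc2Cl)cc1OC1CC2CCC1C2`) departs from compound 3 by one change: a group of 7 heavy atoms (7 carbon; 2 five-membered non-aromatic rings of carbon only) in place of a group of 4 heavy atoms (4 carbon; no ring), on an oxygen on an aromatic ring. Among the measured compounds shown here, the only measured step, a 15-fold lower number from compound 1 to compound 2 (1.18 log units; beyond the scatter), is large, but it is 3-chloropyridin-4-yl in place of 2-chlorophenyl on an amide-type nitrogen. For the measured compounds named here, no measured step changes the group on the oxygen, so its size cannot simply be carried over. Compound 2 at 30 nM does show that this series reaches much lower numbers, and compound 4, like compound 1 and compound 2, carries a ring on that oxygen, whereas butyl has none. A lower number is therefore expected, though with wide uncertainty. The expected change is an 8.0-fold lower number from compound 3 to compound 4 (0.90 log units; beyond the scatter). For compound 4 the estimated value in this assay is 60 nM, with an expected range of 12 nM to 250 nM.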

Compound 4, half-maximal inhibitory concentration: 22 nM
For compound 4 the middle estimate is 2.7-fold (0.44 log units) above the measured one; low and high end bracket the measured number.
By their numbers in this assay, from the lowest: compounds 4 and 2 (each within the scatter of the next); then compounds 1 and 3 (each within the scatter of the next).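

In this assay, among the compounds shown here, replacing butyl with the group of 2 five-membered non-aromatic rings of carbon only gives a 22-fold lower number from compound 3 to compound 4 (1.34 log units; beyond the scatter), the first measured step at this place, on an oxygen on an aromatic ring. The group on that oxygen therefore moves the number well beyond the scatter with the rest of the molecule unchanged, and the amide-type nitrogen is no longer the only place with a large step. No measurement available here bears on the reason for this step.

A single pair cannot separate the effect of the ring from that of the larger group: heptyl, an open chain with the same carbon count, would test this. Also open, going by these compounds, is how a ring carrying a hydroxyl or an amine would read on the same oxygen.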